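The compounds below may be only part of what the source reports. "The series", "measured", "known", "first", "only" and "open" are said of these compounds alone.

Three compounds share one core and differ only in the group on a six-membered aromatic ring of carbon only. Compound 1 `S=c1oc(-c2ccc3c(c2)OCCO3)nn1CN1CCN(c2ccc(Cl)cc2)CC1` carries chloro there. In a functional assay on HeLa cells (Homo sapiens) for antiproliferative activity, read by MTT assay, with a stated time of 48 h (on this read-out higher numbers stand for weaker inhibition and lower numbers for stronger inhibition), compound 1 gives only a limit, > 50000 nM. Compound 2 `Fc1ccc(N2CCN(Cn3nc(-c4ccc5c(c4)OCCO5)oc3=S)CC2)cc1` carries fluoro instead. In this assay compound 2 likewise gives only a limit, > 50000 nM. Compound 3 `COc1ccc(N2CCN(Cn3nc(-c4ccc5c(c4)OCCO5)oc3=S)CC2)cc1` carries methoxy. In this assay compound 3 also gives only a limit, > 50000 nM. Compound 3 thus stands at the same limit as the other two, and no order among the three can be drawn. The steps a step that the two limits leave unreadable from compound 1 to compound 2, a step that the two limits leave unreadable from compound 1 to compound 3 and a step that the two limits leave unreadable from compound 2 to compound 3 stay unreadable because the limit of > 50000 nM in this assay, at which 3 of the 3 values shown sit, caps every one of them.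

Compound 4 `O=[N+]([O-])c1ccc(N2CCN(Cn3nc(-c4ccc5c(c4)OCCO5)oc3=S)CC2)cc1` is the next variation: nitro in place of methoxy on an aromatic carbon, that is, 4-methoxyphenyl becomes 4-nitrophenyl. Among the measured compounds shown here, none of the measured steps has a readable size, so nothing in the data points to a gain or a loss. The step that the limit leaves unreadable from compound 3 to compound 4 is therefore expected to be none beyond the scatter, most likely ending at another limit. For compound 4 in this assay the estimate is 60000 nM, within 20000 nM to 200000 nM.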

Compound 4, half-maximal inhibitory concentration: 31700 nM
Estimate against measurement, compound 4: 1.9-fold (0.28 log units) above; low and high end bracket the measured number.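

Compound 4 is the only one of the four shown that gives a number rather than a limit in this assay, so with 4-nitrophenyl in place of 4-methoxyphenyl this position gives a readable value for the first time. The change reads as an at least 1.5-fold lower number from compound 3 to compound 4 (0.19 log units; that floor lies within the scatter), and the comparisons with the other two compounds read as an at least 1.5-fold lower number from compound 2 to compound 4 (0.19 log units; that floor lies within the scatter) and an at least 1.5-fold lower number from compound 1 to compound 4 (0.19 log units; that floor lies within the scatter), so no real gain for nitro over methoxy, fluoro or chloro is established. Each step is known only as a floor because its other end is a limit: the limit of > 50000 nM in this assay, at which 3 of the 4 values shown sit.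

As far as these compounds go, the true size of all three steps remains open. From the compounds shown here alone, it is also open whether an amine or a carboxylic acid at this place would move the number beyond the scatter.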